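Trifluoromethyl for ethyl on the aryl ring

This account rests on a few compounds, and the source may have more. Where it says the series, first, only, none or still open, it means among the compounds named here.

Compounds measured in a functional assay on cells (T-cell, Homo sapiens) for inhibition; on this read-out higher numbers stand for weaker inhibition and lower numbers for stronger inhibition:
compound 1, `CCOc1nc(N)nc2ncc(-c3ccc(OC)cc3)nc12`: > 10000 nM
compound 2, `CC(C)Oc1nc(N)nc2ncc(-c3ccc(C(F)(F)F)cc3)nc12`: > 10000 nM
compound 3, `CCOc1nc(N)nc2ncc(-c3ccc(CC)cc3)nc12`: 8200 nM

Among the measured compounds shown here, compound 3 gives 8200 nM in this assay, the only number in the set. For compound 1 the result is a limit, > 10000 nM. For compound 2 the result is likewise a limit, > 10000 nM. Two of the three results thus sit at the limit of > 10000 nM in this assay, at which 2 of the 3 values shown sit. For the measured compounds named here, the single measured step, an at least 1.2-fold lower number from compound 1 to compound 3 (0.08 log units; that floor lies within the scatter), does not leave the scatter. Compound 4 `CCOc1nc(N)nc2ncc(-c3ccc(C(F)(F)F)cc3)nc12` differs from compound 3 by trifluoromethyl in place of ethyl on an aromatic carbon. Going by the values given here, no measured step covers this change; compound 2 carries the same trifluoromethyl group with a different ether and sits at a limit. Compound 4 is therefore expected to show weaker inhibition, a step of a 1.6-fold higher number from compound 3 to compound 4 (0.20 log units; within the scatter). The estimate for compound 4 is 13000 nM, between 5000 nM and 35000 nM.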

Compound 4, half-maximal inhibitory concentration: 10000 nM
For compound 4 the middle estimate is 1.3-fold (0.11 log units) above the measured one; low and high end bracket the measured number.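

In this assay trifluoromethyl in place of ethyl on this aromatic carbon, para to a large group, gives a step that stays within the scatter (a 1.2-fold higher number from compound 3 to compound 4 (0.09 log units; within the scatter)). On this read-out, the two groups cannot be told apart at this position. Two further steps, (a number no higher from compound 2 to compound 4 (the limit leaves the size open)) and (a number no higher from compound 1 to compound 4 (the limit leaves the size open)), cannot be read because the results for compound 1 and compound 2 are limits: the limit of > 10000 nM in this assay, at which 2 of the 4 values shown sit.

In this assay the compounds shown leave open how an amine, a carboxylic acid or a longer chain on this carbon would read. They also leave open whether any group here moves the number beyond the scatter.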